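The source may hold more compounds than are shown below. What is called first, only, known or untested is meant among the compounds shown, and "the series" means these compounds.

Measured so far:
- Compound 1 `NS(=O)(=O)c1ccc(N/C(S)=N\c2ccnc3cc(C(F)(F)F)ccc23)cc1` gives 52900 nM
- Compound 2 `N=C(N)NS(=O)(=O)c1ccc(N/C(S)=N\c2ccnc3cc(C(F)(F)F)ccc23)cc1` gives "not active" (no number reported)
- Compound 3 `Cc1cc(NS(=O)(=O)c2ccc(N/C(S)=N\c3ccnc4cc(C(F)(F)F)ccc34)cc2)on1` gives 80300 nM

All three were tested in a functional assay on MDA-MB-231 cells (Homo sapiens) for antiproliferative activity, read by sulforhodamine B assay, with a stated time of 48 h; on this read-out lower numbers stand for stronger inhibition and higher numbers for weaker inhibition. Compound 3 has the highest of the two numbers, with compound 1 nearest and within the scatter; compound 2 returned no number at all. Compound 4 `O=S(=O)(Nc1ccccn1)c1ccc(N/C(S)=N\c2ccnc3cc(C(F)(F)F)ccc23)cc1` differs from compound 3 in one place: pyridin-2-yl in place of 3-methyl-1,2-oxazol-5-yl on a sulfonamide nitrogen. For the measured compounds named here, the only measured step that bears on a ring placed on this sulfonamide nitrogen is a 1.5-fold higher number from compound 1 to compound 3 (0.18 log units; within the scatter), which was within the scatter. Going by the values given here, no measured step exchanges one ring for another at this position, so the expectation is weak. Compound 4 is therefore expected to stay near compound 3, with a 1.1-fold lower number from compound 3 to compound 4 (0.06 log units; within the scatter). The estimate for compound 4 is 70000 nM, in a range from 30000 nM to 200000 nM.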

Compound 4, half-maximal inhibitory concentration: 49300 nM
Estimate against measurement, compound 4: 1.4-fold (0.15 log units) above, and the stated range covers the measured number.
By their numbers in this assay, from the lowest: compounds 4, 1 and 3 (each within the scatter of the next).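

In this assay, for the compounds shown here, there is a 1.6-fold lower number from compound 3 to compound 4 (0.21 log units; within the scatter) when pyridin-2-yl replaces 3-methyl-1,2-oxazol-5-yl on the sulfonamide nitrogen, the first exchange of one ring for another at this position. Against hydrogen on that nitrogen there is a 1.1-fold lower number from compound 1 to compound 4 (0.03 log units; within the scatter) when pyridin-2-yl enters, so this six-membered ring, like the five-membered one, leaves the number within the scatter of the unsubstituted sulfonamide. Nothing available explains why these numbers stay so close.

From the compounds shown here alone, whether a ring carrying an amine or a carboxylic acid would shift the number remains open. So does the effect of an open butyl chain on this nitrogen.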